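Chromobox 7 displacement series: carbonyl to sulfonyl at the amine

A few compounds are considered here, and "the series" means these few. Any claim that something is new, unique, unknown or untested is made for them only; others in the source may bear on it.

Measured compounds in an assay on isolated protein for displacement of a labelled ligand from Chromobox protein homolog 7 (Homo sapiens), read by fluorescence polarization, with a stated time of 15 min; a lower number here means a stronger inhibitor, a higher number a weaker inhibitor:
compound 1 `CC(C)C[C@H](NC(=O)[C@H](C)NC(=O)c1ccccc1)C(=O)N[C@@H](CCCC[N+](C)(C)C)C(=O)N[C@@H](CO)C(N)=O` gives 57000 nM
compound 2 `CC(C)C[C@H](NC(=O)[C@H](C)NC(=O)c1cccnc1)C(=O)N[C@@H](CCCC[N+](C)(C)C)C(=O)N[C@@H](CO)C(N)=O` gives 91000 nM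
compound 3 `CC(C)C[C@H](NC(=O)[C@H](C)NC(=O)CNC(=O)c1ccccc1)C(=O)N[C@@H](CCCC[N+](C)(C)C)C(=O)N[C@@H](CO)C(N)=O` gives 58000 nM

Compound 2 has the highest number of the three, yet its distances to compound 1 and compound 3 are both within the scatter, so no ordering among them is claimed. Compound 4 `CC(C)C[C@H](NC(=O)[C@H](C)NS(=O)(=O)c1cccnc1)C(=O)N[C@@H](CCCC[N+](C)(C)C)C(=O)N[C@@H](CO)C(N)=O` differs from compound 2 by (pyridin-3-yl)sulfonyl in place of (pyridin-3-yl)carbonyl on an amine nitrogen. Going by the values given here, no measured step replaces a carbonyl by a sulfonyl on that nitrogen. The steps at the same end of the chain, a 1.6-fold higher number from compound 1 to compound 2 (0.20 log units; within the scatter) and a 1.6-fold lower number from compound 2 to compound 3 (0.20 log units; within the scatter), both stayed within the scatter, as did a 1.0-fold higher number from compound 1 to compound 3 (0.01 log units; within the scatter). This assay has so far been insensitive to changes here, so the step of a 1.0-fold lower number from compound 2 to compound 4 (0.00 log units; within the scatter) is expected to remain within the scatter. Compound 4 is therefore estimated at 90000 nM, with a range of 40000 nM to 200000 nM.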

Compound 4, half-maximal inhibitory concentration: > 250000 nM
Compound 4: only a limit was reported; the forecaster's own chance of this, stated with the estimate: 25%; middle value at least 2.7-fold (0.44 log units) away from the limit.
By their numbers in this assay, from the lowest: compounds 1, 3 and 2 (each within the scatter of the next). At a limit, above all of these: compound 4.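

At the amine nitrogen, swapping the carbonyl for a sulfonyl registers where the earlier changes on the carbonyl carbon did not: in this assay, (pyridin-3-yl)sulfonyl in place of (pyridin-3-yl)carbonyl gives an at least 2.7-fold higher number from compound 2 to compound 4 (0.43 log units; beyond the scatter). The other two comparisons, an at least 4.3-fold higher number from compound 3 to compound 4 (0.63 log units; beyond the scatter) and an at least 4.3-fold higher number from compound 1 to compound 4 (0.64 log units; beyond the scatter), also lie beyond the scatter, unlike every step among the first three compounds. Each of these sizes is only a floor: the limit of > 250000 nM in this assay, at which 1 of the 4 values shown sits.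

On these data alone, whether a phenylsulfonyl group on this nitrogen would behave like (pyridin-3-yl)sulfonyl remains open. So does how far the true value of compound 4 lies past the limit.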